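Benzyloxy Replacement on the Anilide Compound 3

A few compounds are considered here, and "the series" means these few. Any claim that something is new, unique, unknown or untested is made for them only; others in the source may bear on it.

Three compounds sharing a hydroxamic acid core were tested in a functional assay on NFF cells (Homo sapiens) for antiproliferative activity; a higher number here means a weaker inhibitor, a lower number a stronger inhibitor. Compound 1 `O=C(/C=C/c1ccccc1)N[C@@H](CCCCCC(=O)NO)C(=O)NCc1ccccc1` gives 4010 nM. Compound 2 `O=C(CCCCC[C@H](NC(=O)OCc1ccccc1)C(=O)NCc1ccccc1)NO`, which carries benzyloxy in place of 2-phenylethenyl on a carbonyl carbon, gives 1520 nM; that change is the step of a 2.6-fold lower number from compound 1 to compound 2 (0.42 log units; beyond the scatter). Compound 3 `CN(C)c1ccc(NC(=O)[C@H](CCCCCC(=O)NO)NC(=O)/C=C/c2ccccc2)cc1`, with 4-(dimethylamino)phenyl in place of benzyl on an amide-type nitrogen, gives 240 nM, the step of a 17-fold lower number from compound 1 to compound 3 (1.22 log units; beyond the scatter). Compound 3 thus stands lowest of the three numbers, beyond the scatter from both compound 2 and compound 1.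

Compound 4 `CN(C)c1ccc(NC(=O)[C@H](CCCCCC(=O)NO)NC(=O)OCc2ccccc2)cc1` has not yet been measured in this assay. It differs from compound 3 as follows: benzyloxy in place of 2-phenylethenyl on a carbonyl carbon This is the same change as between compound 1 and compound 2, where the step was a 2.6-fold lower number from compound 1 to compound 2 (0.42 log units; beyond the scatter), a modest move toward a lower number. Within the data shown here, the one measured instance of this change therefore points to a modest decrease for compound 4 relative to compound 3, though it rests on a single pair, and no measured pair shows how the change behaves when 4-(dimethylamino)phenyl is present on the amide-type nitrogen. Compound 4 is therefore expected to show a 2.5-fold lower number from compound 3 to compound 4 (0.40 log units; beyond the scatter). The estimate for compound 4 is 95 nM, with a range from 40 nM to 250 nM.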

Compound 4, half-maximal inhibitory concentration: 650 nM
Compound 4: the middle estimate sits 6.8-fold (0.84 log units) below what was measured, and the stated range ends below it.
By their numbers in this assay, from the lowest: compound 3; then compound 4; then compound 2; then compound 1.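

On the core carrying 4-(dimethylamino)phenyl, benzyloxy in place of 2-phenylethenyl on the carbonyl carbon gives a 2.7-fold higher number from compound 3 to compound 4 (0.43 log units; beyond the scatter), so the direction of this change depends on the group on the amide-type nitrogen: the same change on two cores in this assay, a 2.6-fold lower number (0.42 log units; beyond the scatter) from compound 1 to compound 2 and a 2.7-fold higher number (0.43 log units; beyond the scatter) from compound 3 to compound 4, 7.1-fold (0.85 log units) apart, beyond the scatter of two such steps. Read the other way, 4-(dimethylamino)phenyl in place of benzyl on the amide-type nitrogen still lowers the number when benzyloxycarbonyl replaces (2-phenylethenyl)carbonyl, but the step shrinks to a 2.3-fold lower number from compound 2 to compound 4 (0.37 log units; beyond the scatter): the same change on two cores in this assay, a 17-fold lower number (1.22 log units; beyond the scatter) from compound 1 to compound 3 and a 2.3-fold lower number (0.37 log units; beyond the scatter) from compound 2 to compound 4, 7.1-fold (0.85 log units) apart, beyond the scatter of two such steps. Across these four compounds the two changes therefore do not add, and a step read on one core cannot be carried over to the other in this assay.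

The compounds shown do not explain this coupling between the two places, and they cannot say whether it extends to other groups on the amide-type nitrogen, such as a plain phenyl or a 4-methoxyphenyl. They also leave open how a third group on the carbonyl carbon, such as a 2-phenylethyl with the double bond saturated or a simple methyl, would behave on either core.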